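The source may report more compounds than this note shows. Statements on the series, on what has been measured and on what is new or still open speak of the compounds shown alone.

Measured compounds:
- compound 1, `COc1cc(-c2nc3cc(C)c(C)cc3[nH]2)cc(I)c1O`, 1770 nM
- compound 2, `COc1cc(-c2nc3cc(F)ccc3[nH]2)ccc1OC(C)=O`, 1680 nM

Of the compounds shown here, two have been measured in an assay for inhibition of Alpha amylase (Homo sapiens), with a stated time of 10 min; on this read-out lower numbers stand for stronger inhibition and higher numbers for weaker inhibition. Compound 1 `COc1cc(-c2nc3cc(C)c(C)cc3[nH]2)cc(I)c1O` gives 1770 nM in this assay. Compound 2 `COc1cc(-c2nc3cc(F)ccc3[nH]2)ccc1OC(C)=O` gives 1680 nM in this assay. The two numbers lie within the usual scatter of each other, so neither compound can be said to inhibit more strongly than the other; compound 2 simply sits alongside compound 1 at the level both share.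

Compound 3 `COc1cc(-c2nc3cc(Cl)ccc3[nH]2)ccc1OC(C)=O` has not yet been measured. Compared with compound 2, the change is chloro in place of fluoro on an aromatic carbon. Among the compounds with values here, no pair of measured compounds differs by such a swap, so there is no measured step to lean on. With only one changed atom and no change in ring count, donors, acceptors or charge, the expected step is small, at most a modest move toward stronger inhibition, and it may well stay within the scatter.

For compound 3 the expected value in this assay is 1300 nM, with a range from 500 nM to 3500 nM, which corresponds to an estimated step of a 1.3-fold lower number from compound 2 to compound 3 (0.11 log units; within the scatter).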

Compound 3, half-maximal inhibitory concentration: 1680 nM
Compound 3: the middle estimate sits 1.3-fold (0.11 log units) below what was measured, and the stated range covers the measured number.
By their numbers in this assay, from the lowest: compounds 2, 3 and 1 (each within the scatter of the next).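

Chloro in place of fluoro on this aromatic carbon gives no change at the digits printed from compound 2 to compound 3 (within the scatter) in this assay, and this is the first step in the series that isolates a single change. Compound 1 differs from compound 2 in more than one place, so that earlier pair could not show what one group at this position contributes. This pair shows that, at this position and on this core, these two halogens cannot be told apart in this assay, although nothing measured here speaks to why they read alike.

As far as these compounds go, what an amine, a nitrile or a carboxylic acid on this same aromatic carbon would do remains open, since a swap of one halogen for another says little about groups of a different kind. Also open, from the compounds shown here alone, is what the other parts of the shared core contribute, since compound 1 differs from compound 2 in several places at once and its value cannot be traced to any single change.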